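Adding a methyl to the piperidine of compound 2

A few compounds are considered here, and "the series" means these few. Any claim that something is new, unique, unknown or untested is made for them only; others in the source may bear on it.

Compound 1 `COc1ncc(-c2ccc3nccc(C#CCN(C)C)c3c2)cc1NS(=O)(=O)c1ccc(F)cc1F` and compound 2 `COc1ncc(-c2ccc3nccc(C#CCN4CCCCC4)c3c2)cc1NS(=O)(=O)c1ccc(F)cc1F` share one core and differ only in the amine on the saturated chain carbon bound to a triple-bonded carbon. In an assay on isolated protein for inhibition of phosphatidylinositol 4,5-bisphosphate 3-kinase catalytic subunit beta isoform (Homo sapiens), read by luminescence and ADP-Glo, with a stated time of 40 min, tested at 10 nM (on this read-out lower numbers stand for less inhibition and higher numbers for more inhibition at the one concentration tested (going by the name of the read-out)), compound 1 gives 41% and compound 2 gives 1.4%; the step of a number 39.6 percentage points lower from compound 1 to compound 2 (beyond the scatter) follows from piperidin-1-yl replacing dimethylamino. Among the compounds with values here, compound 2 therefore stands at the lower of the two numbers measured so far, well apart from compound 1.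

Compound 3 `COc1ncc(-c2ccc3nccc(C#CCN4CCC(C)CC4)c3c2)cc1NS(=O)(=O)c1ccc(F)cc1F` keeps the piperidin-1-yl of compound 2 and carries one further change, (methyl in place of hydrogen on a saturated ring carbon). Within the data shown here, no measured step addresses a methyl on this ring; the only step available, a number 39.6 percentage points lower from compound 1 to compound 2 (beyond the scatter), concerns exchanging the amine itself, not a substituent on it, so it gives no direct guide. With compound 2 already near the bottom of the read-out, little room remains for a fall, and nothing in the data argues for a recovery. Compound 3 is expected to show a step of a number 3.6 percentage points higher from compound 2 to compound 3 (within the scatter), giving an estimate of 5%, within a range of -5% to 25%.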

Compound 3, a percentage reported as inhibition, at one concentration (the size of the read-out at that concentration, not a potency): 5.8%
For compound 3 the middle estimate is 0.8 percentage points below the measured one; the measured number falls inside the stated range.
By their numbers in this assay, from the lowest: compounds 2 and 3 (each within the scatter of the next); then compound 1.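

In this assay, methyl in place of hydrogen on a saturated ring carbon, three ring bonds from the ring nitrogen, gives a number 4.4 percentage points higher from compound 2 to compound 3 (within the scatter), so at this position the methyl cannot be told apart from the hydrogen of the plain piperidin-1-yl. With 4-methylpiperidin-1-yl in place of dimethylamino, the result is a number 35.2 percentage points lower from compound 1 to compound 3 (beyond the scatter), which shows that the large gap to compound 1 is not confined to the unsubstituted piperidin-1-yl but also holds for this substituted ring. No measurement shown here bears on why the numbers fall as they do.

Since compound 2 and compound 3 both sit low on a read-out taken at one concentration, these numbers do not show whether the two compounds would separate at a higher concentration. From the compounds shown here alone, it also remains open whether a hydroxyl group in place of the methyl, or a morpholin-4-yl or pyrrolidin-1-yl amine in place of the piperidine, would stay with these two compounds or move towards compound 1.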